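Carbonyl substituent series: butyl amide for anilide

The compounds below may be only part of what the source reports. "The series", "measured", "known", "first", "only" and "open" are said of these compounds alone.

Of the compounds shown here, three sharing one core have been measured in a functional assay for inhibition of nuclear factor NF-kappa-B complex (Homo sapiens); a higher number here means a weaker inhibitor, a lower number a stronger inhibitor. Compound 1 `COc1ccc2c(c1)OC(c1cc(OC)c(OC)c(OC)c1)C(C(C)=O)=C2` gives 14100 nM; compound 2 `COc1ccc2c(c1)OC(c1cc(OC)c(OC)c(OC)c1)C(C(=O)OCCc1ccccc1)=C2` gives 16200 nM; compound 3 `COc1ccc2c(c1)OC(c1cc(OC)c(OC)c(OC)c1)C(C(=O)Nc1ccccc1)=C2` gives 17500 nM. The three values sit close together: a 1.1-fold higher number from compound 1 to compound 2 (0.06 log units; within the scatter), a 1.2-fold higher number from compound 1 to compound 3 (0.09 log units; within the scatter) and a 1.1-fold higher number from compound 2 to compound 3 (0.03 log units; within the scatter) are all within the scatter, so compound 3 cannot be separated from the others on these numbers.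

Compound 4 `CCCCNC(=O)C1=Cc2ccc(OC)cc2OC1c1cc(OC)c(OC)c(OC)c1` has not yet been measured. Relative to compound 3 the change is butyl in place of phenyl on an amide-type nitrogen. The steps measured so far all exchange the group on the carbonyl carbon and none moves the number beyond the scatter, so no step beyond the scatter is expected here either: a 1.1-fold lower number from compound 3 to compound 4 (0.03 log units; within the scatter). The estimate for compound 4 in this assay is 16500 nM, ranging from 7500 nM to 36000 nM.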

Compound 4, half-maximal inhibitory concentration: 25500 nM
Beside the measured number, compound 4's estimate is 1.5-fold (0.19 log units) below it, within the range that was stated.
By their numbers in this assay, from the lowest: compounds 1, 2, 3 and 4 (each within the scatter of the next).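

In this assay this step acts on the amide-type nitrogen itself, and a 1.5-fold higher number from compound 3 to compound 4 (0.16 log units; within the scatter) follows from exchanging phenyl, with its six-membered aromatic ring, for butyl, with no ring. Set against the carbonyl-carbon groups, butylamino gives a 1.6-fold higher number from compound 2 to compound 4 (0.20 log units; within the scatter) and a 1.8-fold higher number from compound 1 to compound 4 (0.26 log units; within the scatter) as the widest step so far, yet even this stays within the scatter, so a ring on this nitrogen is not required to keep the number in this range. No data bear on the reason for this result.

From the compounds shown here alone, whether a longer chain, a branched chain such as isopropyl or a terminal amine or carboxylic acid on this nitrogen would move the number beyond the scatter remains open. The nitrogen's remaining amide hydrogen also stays untested, as no group is shown replacing it.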